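Swapping a Hydroxypiperidine Amide for a Sulfonamide Chain

The compounds below may be only part of what the source reports. "The series", "measured", "known", "first", "only" and "open" are said of these compounds alone.

Compound 1, `CC(C)(C)c1ccc(C(=O)N2CCC3(CC2)C(=O)N(CC(=O)N2CCC(O)CC2)CN3c2ccccc2)cc1`, gives 4700 nM in an assay on HEK293 cells for displacement of a labelled ligand from NPC1-like intracellular cholesterol transporter 1 (Homo sapiens); a lower number here means a stronger inhibitor, a higher number a weaker inhibitor.
Compound 2, `CCc1nn(CC)c(C2CCN(C(=O)CN3CN(c4ccccc4)C4(CCN(C(=O)c5ccc(C(C)(C)C)cc5)CC4)C3=O)CC2)c1CC`, gives 4600 nM in this assay.

Compound 1 and compound 2 share one core and differ only at the far end of the amide. The step of a 1.0-fold lower number from compound 1 to compound 2 (0.01 log units; within the scatter) is within the scatter, so the two compounds stand at the same level in this assay, and compound 1 has no partner that is clearly stronger or weaker.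

Compound 3, `CC(C)(C)c1ccc(C(=O)N2CCC3(CC2)C(=O)N(CC(=O)NCCCCNS(C)(=O)=O)CN3c2ccccc2)cc1`, has not yet been measured. It differs from compound 1 in the same region: (4-(methanesulfonamido)butyl)amino in place of 4-hydroxypiperidin-1-yl on a carbonyl carbon. The change opens the ring into a chain that ends in a methanesulfonamide.

Among the compounds with values here, only the step from compound 1 to compound 2 bears on this. There, a small hydroxy gave way to a large triethyl-pyrazolyl with no effect beyond the scatter, which suggests this part of the molecule can be altered freely. The expectation for compound 3 is therefore a step of a 1.1-fold higher number from compound 1 to compound 3 (0.03 log units; within the scatter), within the scatter. Compound 3 is estimated at 5000 nM, with a range from 2000 nM to 12000 nM.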

Compound 3, half-maximal inhibitory concentration: 4500 nM
For compound 3 the middle estimate is 1.1-fold (0.05 log units) above the measured one; low and high end bracket the measured number.
By their numbers in this assay, from the lowest: compounds 3, 2 and 1 (each within the scatter of the next).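

Opening the ring of the 4-hydroxypiperidin-1-yl group into the (4-(methanesulfonamido)butyl)amino chain gives a 1.0-fold lower number from compound 1 to compound 3 (0.02 log units; within the scatter) in this assay and so leaves compound 1 and compound 3 at the same level. Compound 2 kept the six-membered ring of compound 1 and differed only in the group on that ring, so the earlier pair could not show whether the ring itself matters; compound 3 shows that a chain with no ring, ending in a methanesulfonamide, can stand on this carbonyl carbon with the number staying within the scatter. The data offer no measurement that explains why such different groups give matching numbers.

On these data alone, all three groups on this carbonyl carbon read alike, so it remains open whether any group placed here can move the number beyond the scatter. An amine or a carboxylic acid at the end of the chain, or a shorter or longer chain than the butyl one in compound 3, would test whether this end of the molecule has any influence on the result.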